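Replacing a Hydroxy Lactam with a Morpholinone

A few compounds are considered here, and "the series" means these few. Any claim that something is new, unique, unknown or untested is made for them only; others in the source may bear on it.

Measured so far in an ADME assay on microsomes from liver (Homo sapiens) for metabolic stability, read by LC-MS, using NADPH, with a stated time of 30 min, tested at 1 uM; a higher number here means faster removal of the compound, a lower number slower removal:
- compound 1 `CC(C)c1noc(N2CCC(Oc3cc(N4CCc5cc(N6CCCNS6(=O)=O)ccc54)ncn3)CC2)n1`: 79 mL.min-1.g-1
- compound 2 `CC(C)c1noc(N2CCC(Oc3cc(N4CCc5cc(N6CC(O)CCC6=O)ccc54)ncn3)CC2)n1`: 1 mL.min-1.g-1

Of these two compounds, compound 2 has the lower number, at 1 mL.min-1.g-1, so it marks the slow-removal end of what has been seen in this assay. The next compound, compound 3 `CC(C)c1noc(N2CCC(Oc3cc(N4CCc5cc(N6CCOCC6=O)ccc54)ncn3)CC2)n1`, keeps the shared core and changes one group: 3-oxomorpholin-4-yl in place of 5-hydroxy-2-oxopiperidin-1-yl on an aromatic carbon.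

Among the compounds with values here, only one measured step bears on this change. It involves a different exchange of ring groups at the same place, and it gave a 79-fold lower number from compound 1 to compound 2 (1.90 log units; beyond the scatter), well beyond the scatter. That step shows that the number can move strongly with the group at this place. Within the data shown here, no measured compound carries the 3-oxomorpholin-4-yl group, however, so the size of the next move is uncertain. Since compound 2 sits at 1 mL.min-1.g-1, a rise is expected, though a much smaller one than the measured step. The expected change is a 6.0-fold higher number from compound 2 to compound 3 (0.78 log units; beyond the scatter). For compound 3 the estimated value is 6 mL.min-1.g-1, with an expected range of 1.5 mL.min-1.g-1 to 25 mL.min-1.g-1.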

Compound 3, intrinsic clearance in microsomes: 27 mL.min-1.g-1
Beside the measured number, compound 3's estimate is 4.5-fold (0.65 log units) below it, outside the stated range (above it).
By their numbers in this assay, from the lowest: compound 2; then compound 3; then compound 1.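

In this assay, 3-oxomorpholin-4-yl in place of 5-hydroxy-2-oxopiperidin-1-yl gave a large rise (a 27-fold higher number from compound 2 to compound 3 (1.43 log units; beyond the scatter)), so the very low number of compound 2 does not carry over to every six-membered non-aromatic ring with a carbonyl at this aromatic carbon, even though both groups have the same count of hydrogen-bond acceptors and no net charge. Against the sulfur-containing ring of compound 1, the same group gave only a modest fall (a 2.9-fold lower number from compound 1 to compound 3 (0.47 log units; beyond the scatter)), which places compound 3 between the other two compounds and much closer to compound 1 than to compound 2. Among these three groups, the low end of the range therefore belongs to the 5-hydroxy-2-oxopiperidin-1-yl group alone, and nothing given here accounts for why the number moves as it does.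

The step from compound 2 to compound 3 removes the hydroxy group and brings in the ring oxygen together, so the compounds shown do not tell which of the two goes with the rise. Also open, from the compounds shown here alone, is how a plain 2-oxopiperidin-1-yl group, or a hydroxy group placed on the 3-oxomorpholin-4-yl ring, would read at this aromatic carbon.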